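From (4-methylpiperazin-1-yl)carbonyl to carboxy: a growth-inhibition step

The compounds below may be only part of what the source reports. "The series", "measured", "known", "first", "only" and "open" are said of these compounds alone.

Compound 1 `CN1CCN(C(=O)/C=C/c2ccncc2-c2ccc3ccccc3c2)CC1` was examined in a functional assay on HCT-116 cells (Homo sapiens) for inhibition, read by MTT assay, with a stated time of 72 h; on this read-out higher numbers stand for weaker inhibition of growth and lower numbers for stronger inhibition of growth. Compound 1 gives > 30000 nM, which is a limit of the assay and not a number. That places compound 1 at the limit of > 30000 nM in this assay, at which 1 of the 3 values shown sits.

Two further compounds give little direct guidance. Compound 2 `CCOC(=O)/C=C/c1ccncc1-c1ccc2c(cnn2C)c1` differs from compound 1 in more than one place. In this assay compound 2 gives 1330 nM. For compound 3 `Cn1ncc2cc(-c3cnccc3/C=C/C(=O)N3CCOCC3)ccc21`, the entry reads "not determined" (no result reported).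

The step followed here leads to compound 4 `O=C(O)/C=C/c1ccncc1-c1ccc2ccccc2c1`. The change is hydroxy in place of 4-methylpiperazin-1-yl on a carbonyl carbon. In words, hydroxy stands in place of 4-methylpiperazin-1-yl on a carbonyl carbon, so that (4-methylpiperazin-1-yl)carbonyl becomes carboxy. Going by the values given here, no two measured compounds differ in one place, so this change has no measured precedent.

Growth inhibition is expected to remain weak, with no step beyond the scatter in either direction. The expected change is a number no higher from compound 1 to compound 4 (the limit leaves the size open). This expectation rests on the limit reached by compound 1 at > 30000 nM, and a reported limit is at least as likely as a number. For compound 4, the estimated concentration for growth inhibition is 30000 nM, with an expected range from 8000 nM to 100000 nM.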

Compound 4, concentration for 50% growth inhibition: > 30000 nM
Compound 4 gave a limit, no number (the forecaster's own chance of this, stated with the estimate: 55%); the middle value sits exactly at the limit.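

In this assay, going by these compounds alone, compound 4 gives > 30000 nM, a limit of the assay and not a number, and compound 1 also stands at a limit, so no step between compound 1 and compound 4 can be read. The compounds shown leave open the size and direction of any effect on growth inhibition of hydroxy in place of 4-methylpiperazin-1-yl on a carbonyl carbon.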